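Changing the aryl on the triazole of a spiro series

The source may hold more compounds than are shown below. What is called first, only, known or untested is meant among the compounds shown, and "the series" means these compounds.

Two members of a shared core, compound 1, `N#CC1=C(N)Oc2c(c3nc4ccccc4nc3c3ccccc23)C12C(=O)N(Cc1cnnn1-c1ccc(F)c(Cl)c1)c1ccccc12`, and compound 2, `N#CC1=C(N)Oc2c(N)cc3nc4ccccc4nc3c2C12C(=O)N(Cc1cnnn1-c1cccc(C(F)(F)F)c1)c1ccccc12`, have been tested in a functional assay on HCT-116 cells (Homo sapiens) for antiproliferative activity, read by MTT assay, with a stated time of 48 h; on this read-out higher numbers stand for weaker inhibition and lower numbers for stronger inhibition. Compound 1 returns only a limit of the assay, > 50000 nM, which is the limit of > 50000 nM in this assay, at which 1 of the 2 values shown sits. Among the measured compounds shown here, compound 2 gives the only number in this assay, 18900 nM, and so stands alone among the values shown, with nothing to rank it against. Compound 3, `COc1ccc(OC)c(-n2nncc2CN2C(=O)C3(C(C#N)=C(N)Oc4c(N)cc5nc6ccccc6nc5c43)c3ccccc32)c1`, has not yet been measured in this assay; it differs from compound 2 by 2,5-dimethoxyphenyl in place of 3-(trifluoromethyl)phenyl on an aromatic nitrogen. For the measured compounds named here, no step between two measured compounds exists here that would show how such a change acts. The chemist expects compound 3 to move little from compound 2 in this assay, an estimated step of a 1.1-fold higher number from compound 2 to compound 3 (0.02 log units; within the scatter), in no direction beyond the usual scatter. His estimate for compound 3 is 20000 nM, with a range from 6000 nM to 60000 nM.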

Compound 3, half-maximal inhibitory concentration: > 50000 nM
Compound 3: only a limit was reported; the forecaster's own chance of this, stated with the estimate: 30%; middle value at least 2.5-fold (0.39 log units) away from the limit.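

The series now has its first readable step at this aromatic nitrogen in this assay: putting 2,5-dimethoxyphenyl in place of 3-(trifluoromethyl)phenyl gives an at least 2.6-fold higher number from compound 2 to compound 3 (0.42 log units; beyond the scatter), so the aryl group here can shift the read-out beyond the scatter. Compound 3 gives > 50000 nM, which is a limit of the assay and not a number, and the full size of the step remains unread. Only compound 2 has a number in this small set, and a limit now marks both other compounds: the limit of > 50000 nM in this assay, at which 2 of the 3 values shown sit.

The compounds shown leave open whether one methoxy group alone, at either of the two positions in 2,5-dimethoxyphenyl, would give the same step. As far as these compounds go, it also remains open how an amine or a carboxylic acid on this phenyl ring would read in this assay.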